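A few compounds are considered here, and "the series" means these few. Any claim that something is new, unique, unknown or untested is made for them only; others in the source may bear on it.

Measured compounds:
compound 1 `Cc1cc(S(=O)(=O)NC(=O)Nc2ccc(Cl)cc2)cc2ccoc12`, giving 89% in a functional assay on the whole organism (Mus musculus) for inhibition, at a dose of 150 mg/kg by the oral route; on this read-out higher numbers stand for more inhibition at the one dose given (going by the name of the read-out) and lower numbers for less inhibition
compound 2 `Cc1coc2ccc(S(=O)(=O)NC(=O)Nc3ccc(Cl)cc3)cc12`, giving 44% in this assay
compound 3 `COc1ccc2oc(S(=O)(=O)NC(=O)Nc3ccc(Cl)cc3)cc2c1`, giving 25% in this assay

Compound 3 stands lowest of the three numbers in this assay. Its nearest neighbour on this read-out is compound 2, whose number lies beyond the scatter above it, and compound 1 lies further above still, also beyond the scatter. Compound 4 `Cc1ccc2oc(S(=O)(=O)NC(=O)Nc3ccc(Cl)cc3)cc2c1` differs from compound 3 in one place: methyl in place of methoxy on an aromatic carbon. For the measured compounds named here, no measured pair shows this change, so its effect is unknown from the data. The step from compound 3 to compound 4 is expected to be small, at most a modest rise, estimated as a number 10 percentage points higher from compound 3 to compound 4 (within the scatter). Compound 4 is therefore expected to give about 35% in this assay, estimated to fall between 10% and 65%.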

Compound 4, a percentage reported as inhibition, in the whole organism at one dose (the size of the read-out at that dose, not a potency): 6%
Compound 4: the middle estimate sits 29 percentage points above what was measured; the whole stated range lies above it.
By their numbers in this assay, from the lowest: compound 4; then compound 3; then compound 2; then compound 1.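

In this assay, methyl in place of methoxy on this aromatic carbon gives a number 19 percentage points lower from compound 3 to compound 4 (beyond the scatter). For the compounds shown here, this is the first measured change at a single position, and it shows that the number responds to which of these two groups sits there, with methoxy the better of the pair. Nothing available on these compounds accounts for the step. As far as these compounds go, whether an amine or a hydroxyl group on this carbon would match methoxy remains open. So does whether the same exchange would behave alike on another aromatic carbon.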